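Hydroxy for fluoro on the anilide ring of compound 1

The compounds below may be only part of what the source reports. "The series", "measured", "known", "first", "only" and "open" are said of these compounds alone.

Compound 1 `CC(O)(C(=O)Nc1ccc(S(=O)(=O)c2ccccc2)c(F)c1)C(F)(F)F` was tested in a functional assay (Cavia porcellus) with sulfonylurea receptors; K-ATP channels (Homo sapiens) as the target (a lower number here means a stronger inhibitor, a higher number a weaker inhibitor), alongside compound 2 `CC(O)(C(=O)Nc1ccc(C#N)c(S(=O)(=O)c2ccccc2)c1)C(F)(F)F` and compound 3 `CC(O)(C(=O)Nc1ccc(S(=O)(=O)c2ccccc2C#N)cc1)C(F)(F)F`. In this assay compound 1 gives 1800 nM, compound 2 gives 2600 nM and compound 3 gives 1100 nM; the number for compound 1 stands second highest of the three, and its gaps to compound 2 and to compound 3 are both within the usual scatter. Compound 4 `CC(O)(C(=O)Nc1ccc(S(=O)(=O)c2ccccc2)c(O)c1)C(F)(F)F` has not yet been measured. It differs from compound 1 by hydroxy in place of fluoro on an aromatic carbon. Among the compounds with values here, no measured pair shows this change, so compound 4 is expected to come out close to compound 1, with a step of a 1.4-fold higher number from compound 1 to compound 4 (0.14 log units; within the scatter) that need not exceed the scatter. Compound 4 is therefore estimated at 2500 nM, within 900 nM to 7000 nM.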

Compound 4, half-maximal inhibitory concentration: 430 nM
Beside the measured number, compound 4's estimate is 5.8-fold (0.76 log units) above it; the whole stated range lies above it.
By their numbers in this assay, from the lowest: compound 4; then compounds 3, 1 and 2 (each within the scatter of the next, the first and the last beyond it).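

In this assay hydroxy in place of fluoro on this aromatic carbon, ortho to a group of 9 heavy atoms, gives a 4.2-fold lower number from compound 1 to compound 4 (0.62 log units; beyond the scatter) and so marks this position as one where a single change moves the number beyond the scatter. Within the data shown here, no two of the earlier compounds differ in one place, so they could show no such step. Nothing at hand accounts for this step. As far as these compounds go, whether an amine or a methoxy group on the same carbon would follow hydroxy remains open, as does whether the change carries over to the nitrile compounds.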